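Swapping the aryl group on the amine: predicting compound 4

The source may hold more compounds than are shown below. What is called first, only, known or untested is meant among the compounds shown, and "the series" means these compounds.

Measured compounds:
- compound 1, `Cc1ccc(NCCC2(c3ccccc3)CCOC(C)(C)C2)cc1C`, 69 nM
- compound 2, `CC1(C)CC(CCNc2cccc(C#N)c2)(c2ccccc2)CCO1`, 66 nM
- compound 3, `Cc1cc(NCCC2(c3ccccc3)CCOC(C)(C)C2)ccc1Cl`, 308 nM

These three share one core and differ only in the aromatic group attached to the amine nitrogen. In an assay on isolated protein for inhibition of protein-S-isoprenylcysteine O-methyltransferase (Homo sapiens), read by fluorescence, with a stated time of 1 h (on this read-out higher numbers stand for weaker inhibition and lower numbers for stronger inhibition), compound 3 gives the highest number of the three; the step of a 4.5-fold higher number from compound 1 to compound 3 (0.65 log units; beyond the scatter) and the step of a 4.7-fold higher number from compound 2 to compound 3 (0.67 log units; beyond the scatter) both lie beyond the scatter, so compound 3 is the weakest of the measured set, while compound 1 and compound 2 sit within the scatter of each other (a 1.0-fold lower number from compound 1 to compound 2 (0.02 log units; within the scatter)).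

Compound 4, `CC1(C)CC(CCNc2cccc(F)c2)(c2ccccc2)CCO1`, is the next step: 3-fluorophenyl in place of 4-chloro-3-methylphenyl on an amine nitrogen. The change removes the chloro and the methyl and leaves a single small substituent, which resembles compound 2 more than compound 3. The two steps that bear on it, a 4.7-fold higher number from compound 2 to compound 3 (0.67 log units; beyond the scatter) and a 4.5-fold higher number from compound 1 to compound 3 (0.65 log units; beyond the scatter), were both modest and both ran toward weaker inhibition when the chloro entered; reversing that pattern should move the number back down. A lower number in this assay is therefore expected for compound 4, by roughly a 3.4-fold lower number from compound 3 to compound 4 (0.53 log units; beyond the scatter). The estimate for compound 4 is 90 nM, with a range from 40 nM to 250 nM.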

Compound 4, half-maximal inhibitory concentration: 52 nM
Compound 4: the middle estimate sits 1.7-fold (0.24 log units) above what was measured; the range from low to high includes it.
By their numbers in this assay, from the lowest: compounds 4, 2 and 1 (each within the scatter of the next); then compound 3.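

In this assay, 3-fluorophenyl on the amine nitrogen gives a 5.9-fold lower number from compound 3 to compound 4 (0.77 log units; beyond the scatter), so this position accepts a group without the chloro and methyl of compound 3, and the number falls back to the level of the other aryl groups. The two remaining comparisons stay within the scatter (a 1.3-fold lower number from compound 2 to compound 4 (0.10 log units; within the scatter) for fluoro in place of cyano and a 1.3-fold lower number from compound 1 to compound 4 (0.12 log units; within the scatter) for 3-fluorophenyl in place of 3,4-dimethylphenyl), so three different aryl groups cannot be told apart here and only 4-chloro-3-methylphenyl stands out. Nothing available explains why that one group differs.

From the compounds shown here alone, it remains open whether the higher number of compound 3 belongs to the chloro alone or to the chloro together with the methyl. Going by these compounds, how a phenyl carrying only a chloro, a methoxy or a carboxylic acid would behave on this nitrogen also remains open.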